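The compounds below may be only part of what the source reports. "The series", "measured", "known", "first", "only" and "open" are said of these compounds alone.

Among the measured compounds shown here, compound 1 `COC(=O)CCNC(=O)[C@H]1CC=C(CCC=C(C)C)C[C@@H]1c1ccccc1` is the weaker of the two compounds measured so far in an assay on isolated protein for inhibition of Apoptosis regulator Bcl-2 (Homo sapiens), read by fluorescence polarization, with stated times of 5 min and 10 min; a higher number here means a weaker inhibitor, a lower number a stronger inhibitor: compound 1 gives 3100 nM, whereas compound 2 `CC(C)=CCCC1=CC[C@@H](C(=O)NO)[C@H](c2ccccc2)C1` gives 700 nM, a gap that lies beyond the usual scatter of this assay. Compound 3 `CONC(=O)[C@H]1CC=C(CCC=C(C)C)C[C@@H]1c1ccccc1` has not yet been measured. It differs from compound 1 in a single place: methoxy in place of 2-(methoxycarbonyl)ethyl on an amide-type nitrogen. For the measured compounds named here, no pair of measured compounds differs in only one place, so the size of such a step is not known from measurement. Compound 3 carries a small oxygen-bearing group on the amide-type nitrogen, as does compound 2, whose value of 700 nM lies below that of compound 1. Compound 3 is therefore expected to move downward by a moderate step, a 2.1-fold lower number from compound 1 to compound 3 (0.32 log units; beyond the scatter), beyond the scatter but not reaching compound 2. Compound 3 is estimated at 1500 nM in this assay, with a likely range from 500 nM to 4500 nM.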

Compound 3, inhibition constant: 2400 nM
Compound 3: the middle estimate sits 1.6-fold (0.20 log units) below what was measured, within the range that was stated.
By their numbers in this assay, from the lowest: compound 2; then compounds 3 and 1 (each within the scatter of the next).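

Read in this assay, the change on the amide-type nitrogen from 2-(methoxycarbonyl)ethyl to methoxy gives a 1.3-fold lower number from compound 1 to compound 3 (0.11 log units; within the scatter), so at this position the shorter group and the longer chain cannot be told apart. An oxygen attached to this nitrogen is thus not enough by itself to reach the value of compound 2: compound 3, with methoxy, gives 2400 nM, while compound 2, with hydroxy on the same nitrogen, gives 700 nM. Nothing available explains why this exchange leaves the number within the scatter. On these data alone, it remains open whether a carboxylic acid in place of the methyl ester, an amine at the end of the chain, or a longer chain on this nitrogen would shift the number beyond the scatter. As far as these compounds go, it is also open whether the value of compound 2 would hold on replacing hydroxy with an amino group.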